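Replacing tert-butoxycarbonyl with pyrimidin-2-yl on an amine nitrogen

This account rests on a few compounds, and the source may have more. Where it says the series, first, only, none or still open, it means among the compounds named here.

In a functional assay on NCI-H1975 cells (Homo sapiens) for inhibition, read by MTT assay, with a stated time of 72 h (on this read-out higher numbers stand for weaker inhibition and lower numbers for stronger inhibition), compound 3 `CC(C)(C)OC(=O)N1CCN(c2cc(C(F)(F)F)nc(SCc3ccc(C(F)(F)F)cc3)n2)CC1` gives > 50000 nM, which is a limit and not a number. That places compound 3 at the limit of > 50000 nM in this assay, at which 1 of the 3 values shown sits.

Two relatives with the same core do give numbers. Compound 1 `FC(F)(F)c1ccc(CSc2nc(N3CCNCC3)cc(C(F)(F)F)n2)cc1`, with hydrogen on the amine nitrogen, gives 6210 nM. Compound 2 `CCN1CCN(c2cc(C(F)(F)F)nc(SCc3ccc(C(F)(F)F)cc3)n2)CC1`, with ethyl there, gives 15000 nM.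

Compound 4 `FC(F)(F)c1ccc(CSc2nc(N3CCN(c4ncccn4)CC3)cc(C(F)(F)F)n2)cc1` is still unmeasured. It carries pyrimidin-2-yl in place of tert-butoxycarbonyl on an amine nitrogen in a ring.

Among the compounds with values here, three measured steps bear on this place: a 2.4-fold higher number from compound 1 to compound 2 (0.38 log units; beyond the scatter), an at least 8.0-fold higher number from compound 1 to compound 3 (0.90 log units; beyond the scatter) and an at least 3.3-fold higher number from compound 2 to compound 3 (0.52 log units; beyond the scatter). Hydrogen therefore gave the lowest number of the three groups, but none of the steps puts an aromatic ring there, and the guide is loose. The expectation leans on compound 2, which at 15000 nM shows that a substituted nitrogen can still give a number. The estimated move in this assay is an at least 2.5-fold lower number from compound 3 to compound 4 (0.39 log units; beyond the scatter), toward a lower number. For compound 4 the estimated value is 20000 nM, with an expected range of 7000 nM to 50000 nM.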

Compound 4, half-maximal inhibitory concentration: 18300 nM
Estimate against measurement, compound 4: 1.1-fold (0.04 log units) above, and the stated range covers the measured number.
By their numbers in this assay, from the lowest: compound 1; then compounds 2 and 4 (each within the scatter of the next). At a limit, above all of these: compound 3.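

In this assay, an aromatic ring on this amine nitrogen still gives a measurable number, with an at least 2.7-fold lower number from compound 3 to compound 4 (0.43 log units; beyond the scatter). Compound 3 stands at a limit and not a number, so that step has no exact size: the limit of > 50000 nM in this assay, at which 1 of the 4 values shown sits.

Within the data shown here, the new group also brings something the earlier compounds could not show: pyrimidin-2-yl and ethyl are not told apart here, with a 1.2-fold higher number from compound 2 to compound 4 (0.09 log units; within the scatter), while hydrogen keeps the lowest number, with a 2.9-fold higher number from compound 1 to compound 4 (0.47 log units; beyond the scatter).

The compounds shown leave open whether any group on this nitrogen can give a lower number than hydrogen, such as methyl, a hydroxyethyl chain or acetyl. A plain phenyl ring in the same place would show whether the ring nitrogens of pyrimidin-2-yl matter to the number.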